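A New Aryl Group on the Carbon Double-Bonded to Nitrogen

The source may hold more compounds than are shown below. What is called first, only, known or untested is meant among the compounds shown, and "the series" means these compounds.

Compound 1 `CN(C)CCn1cnnc1-c1cc(Oc2ccc(NC(=O)N/N=C/c3ccc(F)cc3)cc2F)ccn1`: 2310 nM
Compound 2 `COc1cc(/C=N/NC(=O)Nc2ccc(Oc3ccnc(-c4nncn4CCN(C)C)c3)c(F)c2)cc(OC)c1OC`: 22500 nM
Compound 3 `CN(C)CCn1cnnc1-c1cc(Oc2ccc(NC(=O)N/N=C/c3c(O)ccc4ccccc34)cc2F)ccn1`: 620 nM

In a functional assay on U-87MG ATCC cells (Homo sapiens) for cytotoxicity, read by MTT assay, with a stated time of 72 h (a lower number here means a stronger inhibitor, a higher number a weaker inhibitor), compound 1 holds the second highest of the three numbers shown, with compound 3 giving the lowest and compound 2 the highest. Compound 4 `COc1cc(/C=N/NC(=O)Nc2ccc(Oc3ccnc(-c4nncn4CCN(C)C)c3)c(F)c2)ccc1O` has not yet been measured. It differs from compound 1 in one place: 4-hydroxy-3-methoxyphenyl in place of 4-fluorophenyl on a carbon with a double bond to nitrogen. Going by the values given here, two measured steps bear on this change. A methoxy-bearing aryl group gave a 9.7-fold higher number from compound 1 to compound 2 (0.99 log units; beyond the scatter), whereas a hydroxyl-bearing one gave a 3.7-fold lower number from compound 1 to compound 3 (0.57 log units; beyond the scatter). The entering group carries one of each feature, so a modest rise in the number, a 1.7-fold higher number from compound 1 to compound 4 (0.24 log units; within the scatter), is expected. Compound 4 is therefore estimated at 4000 nM, with a range from 1200 nM to 15000 nM.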

Compound 4, half-maximal inhibitory concentration: > 100000 nM
Compound 4 was reported as a limit; the forecaster's own chance of this, stated with the estimate: 5%; middle value at least 25-fold (1.39 log units) away from the limit.
By their numbers in this assay, from the lowest: compound 3; then compound 1; then compound 2. At a limit, above all of these: compound 4.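

In this assay compound 4 gives > 100000 nM, which is a limit and not a number. Going by these compounds alone, this position proves far more sensitive than the earlier compounds showed, with an at least 43-fold higher number from compound 1 to compound 4 (1.63 log units; beyond the scatter), and a hydroxyl on the entering aryl group does not by itself lower the number, with an at least 160-fold higher number from compound 3 to compound 4 (2.20 log units; beyond the scatter). Hydroxyl and methoxy do not offset each other here, since the 3,4,5-trimethoxyphenyl group is also exceeded, with an at least 4.4-fold higher number from compound 2 to compound 4 (0.64 log units; beyond the scatter).

The compounds shown leave open which of the two oxygen groups on the entering ring matters. As far as these compounds go, an amine in place of the hydroxyl, or a phenyl group carrying methoxy alone, remains untested among them.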